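The compounds below may be only part of what the source reports. "The series", "measured", "known", "first", "only" and "open" are said of these compounds alone.

Measured so far:
- compound 1 `CCOC(=O)/C(=C/c1ccccc1)CN1C(=O)[C@@H](OC)[C@H]1c1ccc(Cl)cc1`: 12700 nM
- compound 2 `COC(=O)/C(=C/c1ccccc1)CN1C(=O)[C@@H](OC)[C@H]1c1cccc(Cl)c1`: 25100 nM

In a functional assay on MCF7 cells (Homo sapiens) for antiproliferative activity, read by MTT assay, with a stated time of 48 h (a lower number here means a stronger inhibitor, a higher number a weaker inhibitor), compound 2 gives 25100 nM and compound 1 gives 12700 nM. These two values lie within the usual scatter of each other, so the numbers do not separate the two compounds.

The next compound, compound 3 `COC(=O)/C(=C/c1ccccc1)CN1C(=O)[C@@H](OC)[C@H]1c1cccc([N+](=O)[O-])c1`, keeps the rest of compound 2 and alters one group: nitro in place of chloro on an aromatic carbon. In words, this is nitro in place of chloro on an aromatic carbon, meta to a large group, or 3-chlorophenyl to 3-nitrophenyl.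

Among the compounds with values here, no pair of measured compounds differs in just one place, so the data hold no direct guide to the size or direction of this change. The most cautious expectation in this assay is therefore no shift beyond the scatter, with compound 2 at 25100 nM as the starting point. The estimated step, a 1.3-fold lower number from compound 2 to compound 3 (0.10 log units; within the scatter), is correspondingly small. The range is kept wide to reflect how little evidence there is. For compound 3 the estimated value is 20000 nM, with an expected range from 7000 nM to 55000 nM.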

Compound 3, half-maximal inhibitory concentration: 15000 nM
Estimate against measurement, compound 3: 1.3-fold (0.12 log units) above; the range from low to high includes it.
By their numbers in this assay, from the lowest: compounds 1, 3 and 2 (each within the scatter of the next).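

In this assay the swap of chloro for nitro, on an aromatic carbon meta to a large group, gives a 1.7-fold lower number from compound 2 to compound 3 (0.22 log units; within the scatter), and this is the only comparison among the compounds shown that changes a single place. It shows that, at this position, the nitro group with its 3 heavy atoms and 2 hydrogen-bond acceptors reads the same within the scatter as chloro with its 1 heavy atom and 0 hydrogen-bond acceptors, so this difference between the two groups does not separate the compounds in this test. No independent measurement is available to explain why the two groups read alike.

From the compounds shown here alone, a single pair cannot tell whether this position is generally indifferent to what sits on it, so it remains open whether an amine, a carboxylic acid or a methoxy group there would also stay within the scatter of compound 2. Going by these compounds, it also remains open whether the same swap would read alike in the ethyl ester series of compound 1, where the chloro group sits at a different place on the ring.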